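Methyl on the Aromatic Nitrogen: From Compound 2 to Compound 3

This account rests on a few compounds, and the source may have more. Where it says the series, first, only, none or still open, it means among the compounds named here.

Measured compounds:
Compound 1, `O=S(=O)(c1ccccn1)n1ccc2c(N3CCNCC3)cccc21`: 1 nM
Compound 2, `O=S(=O)(c1cccc(Cl)c1)c1c[nH]c2c(N3CCNCC3)cccc12`: 0.316 nM

In an assay on HeLa cells for displacement of a labelled ligand from 5-hydroxytryptamine receptor 6 (Homo sapiens) (a higher number here means a weaker inhibitor, a lower number a stronger inhibitor), compound 2 gives 0.316 nM, the lowest of the two numbers. Compound 1 gives 1 nM in this assay, a higher number, and the gap between them lies beyond the scatter. Compound 3, `Cn1cc(S(=O)(=O)c2cccc(Cl)c2)c2cccc(N3CCNCC3)c21`, differs from compound 2 by methyl in place of hydrogen on an aromatic nitrogen. Within the data shown here, no pair of measured compounds shows a step of this kind, so its size cannot be read off from the data. The expected change is small, a step of a 1.9-fold higher number from compound 2 to compound 3 (0.28 log units; within the scatter) that stays within the scatter. Compound 3 is therefore expected to give 0.6 nM in this assay, with a range from 0.15 nM to 3 nM.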

Compound 3, inhibition constant: 2.51 nM
Compound 3: the middle estimate sits 4.2-fold (0.62 log units) below what was measured, within the range that was stated.
By their numbers in this assay, from the lowest: compound 2; then compound 1; then compound 3.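

Methyl in place of hydrogen on this aromatic nitrogen in this assay gives a 7.9-fold higher number from compound 2 to compound 3 (0.90 log units; beyond the scatter) and so the step lies beyond the scatter, which means that this position does not accept even this single added carbon without a loss of binding strength. Among these compounds, this is the first change at one place that can be read here, as compound 1 and compound 2 differ in more than one place. The data shown offer no explanation for the size of this step.

Going by these compounds, what ethyl or a longer chain ending in an amine would do on this nitrogen remains open, as does whether the step would stay the same without the chlorine.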